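The compounds below may be only part of what the source reports. "The series", "measured", "known", "first", "only" and "open" are said of these compounds alone.

Of the compounds shown here, three have been tested in a functional assay on KB cells (Homo sapiens) for inhibition (a higher number here means a weaker inhibitor, a lower number a stronger inhibitor), and only one gives a number. Compound 1 `COc1ccc(Cn2c(N)c(C#N)c3c(N)ncnc32)cc1` gives 50000 nM. Compound 2 `N#Cc1c(Br)n(COCc2ccccc2)c2ncnc(N)c12` reads > 100000 nM, which is a limit and not a number. Compound 3 `COCCOCn1c(Br)c(C#N)c2c(N)ncnc21` reads > 100000 nM, which is also a limit. On these data alone, compound 3 therefore stands at the limit of > 100000 nM in this assay, at which 2 of the 3 values shown sit, and its true position is unknown.

Compound 4 `COCCOCn1c(N(C)C)c(C#N)c2c(N)ncnc21` keeps the (2-methoxyethoxy)methyl group of compound 3 and has dimethylamino in place of bromo on an aromatic carbon, (dimethylamino in place of bromo on an aromatic carbon). For the measured compounds named here, the only step between measured compounds, a step that the two limits leave unreadable from compound 2 to compound 3, is methoxymethyl in place of phenyl, a change in a different part of the molecule, and it has no readable size. Going by the values given here, no measured step covers the exchange of bromo for dimethylamino, so no size can be carried over. Among the compounds with values here, the only guide is compound 1 at 50000 nM, which shows that a number can be obtained with this shared core. A small move toward stronger inhibition in this assay is expected, though the reading may well remain at the limit. The estimated step is an at least 1.4-fold lower number from compound 3 to compound 4 (0.15 log units; that floor lies within the scatter), and its size is uncertain. For compound 4 the estimated value is 70000 nM, with an expected range from 20000 nM to 150000 nM.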

Compound 4, half-maximal inhibitory concentration: > 100000 nM
Compound 4: a limit, no number; the forecaster's own chance of this, stated with the estimate: 55%; at least 1.4-fold (0.15 log units) between middle value and limit.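

For the compounds shown here, compound 3 and compound 4 both stand at a limit in this assay, so no step between them can be read: the limit of > 100000 nM in this assay, at which 3 of the 4 values shown sit. The compounds shown leave open whether dimethylamino in place of bromo on an aromatic carbon changes inhibition at all, and where the true values of compound 3 and compound 4 lie.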